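Benzyl-Ether Variants of a Thiourea Series Against Gastric Cancer Cells

The source may hold more compounds than are shown below. What is called first, only, known or untested is meant among the compounds shown, and "the series" means these compounds.

Compound 1 `Cc1ccc(NC(=S)NC(=O)c2ccc(OCc3cccc(Cl)c3)cc2)cc1-c1nc2ccccc2[nH]1`: 43300 nM
Compound 2 `Cc1ccc(NC(=S)NC(=O)c2ccc(OCc3ccc(C(F)(F)F)cc3)cc2)cc1-c1nc2ccccc2[nH]1`: 10200 nM
Compound 3 `Cc1ccc(NC(=S)NC(=O)c2ccc(OCc3cccc(C(F)(F)F)c3)cc2)cc1-c1nc2ccccc2[nH]1`: 6050 nM

All three compounds share one core and differ only in the group carried on a saturated chain carbon bound to an oxygen on an aromatic ring. They were tested in a functional assay on MNK45 cells (Homo sapiens) for inhibition, read by MTT assay, with a stated time of 48 h; a lower number here means a stronger inhibitor, a higher number a weaker inhibitor. Compound 3 gives the lowest number of the three: the step of a 7.2-fold lower number from compound 1 to compound 3 (0.85 log units; beyond the scatter) lies beyond the scatter, whereas the step of a 1.7-fold lower number from compound 2 to compound 3 (0.23 log units; within the scatter) does not, so compound 3 and compound 2 cannot be told apart.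

Compound 4 `Cc1ccc(NC(=S)NC(=O)c2ccc(OCc3ccccc3F)cc2)cc1-c1nc2ccccc2[nH]1` has not yet been measured. The change from compound 3 is 2-fluorophenyl in place of 3-(trifluoromethyl)phenyl on a saturated chain carbon bound to an oxygen on an aromatic ring. Within the data shown here, no measured step swaps trifluoromethyl for a single fluorine or moves a substituent to this position, so the closest guide is a 7.2-fold lower number from compound 1 to compound 3 (0.85 log units; beyond the scatter), where a chloro-bearing ring gave a clearly higher number than the trifluoromethyl-bearing ring. By that guide a smaller halogen is expected to move the number upward rather than down, though by an uncertain amount.

Compound 4 is therefore expected to show a 3.3-fold higher number from compound 3 to compound 4 (0.52 log units; beyond the scatter) in this assay, giving an estimated 20000 nM with a range from 6000 nM to 60000 nM.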

Compound 4, half-maximal inhibitory concentration: 2420 nM
Compound 4: the middle estimate sits 8.3-fold (0.92 log units) above what was measured, outside the stated range (below it).
By their numbers in this assay, from the lowest: compound 4; then compounds 3 and 2 (each within the scatter of the next); then compound 1.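

In this assay, the 2-fluorophenyl group gives a 2.5-fold lower number from compound 3 to compound 4 (0.40 log units; beyond the scatter), so a trifluoromethyl group is not needed for a low number at this position, and a ring with fewer heavy atoms can do better. The same group also gives a 4.2-fold lower number from compound 2 to compound 4 (0.62 log units; beyond the scatter) and an 18-fold lower number from compound 1 to compound 4 (1.25 log units; beyond the scatter), and with all three steps beyond the scatter, compound 4 is the strongest inhibitor of the four. Nothing available here explains this order.

Still open, on these data alone, is whether the low number of compound 4 follows the fluorine itself or the place it holds on the ring. As far as these compounds go, how a plain phenyl ring, or a ring carrying an amine or a carboxylic acid, would compare at this position also remains unknown.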